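From compound 1 to compound 4: one group exchanged

The source may report more compounds than this note shows. Statements on the series, on what has been measured and on what is new or still open speak of the compounds shown alone.

In a functional assay on HepG2 cells (Homo sapiens) for inhibition, read by fluorescence and resazurin assay, with a stated time of 72 h (a lower number here means a stronger inhibitor, a higher number a weaker inhibitor), compound 1 `O=C(Nc1ccccc1)Nc1cccc(Nc2nccc(Nc3ccc4nc[nH]c4c3)n2)c1` gives 11000 nM and compound 2 `O=C1NC(Cc2ccc(Nc3nccc(Nc4ccc5cn[nH]c5c4)n3)cc2)CO1` gives 20000 nM. These two values lie within the scatter of each other, so they do not separate the two compounds. Compound 3 `O=C(Nc1ccccc1)Nc1cccc(Nc2ncc([N+](=O)[O-])c(Nc3ccc4cn[nH]c4c3)n2)c1` gives > 25000 nM, which is a limit of the assay and not a number.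

Compound 4 `Cc1c2ccc(Nc3ccnc(Nc4cccc(NC(=O)Nc5ccccc5)c4)n3)cc2nn1C` keeps the core of compound 1 and carries 2,3-dimethyl-2H-indazol-6-yl in place of 1H-benzimidazol-6-yl on a nitrogen on an aromatic ring. For the measured compounds named here, no pair of measured compounds isolates this exchange, so the series offers no measured step to carry over. The expectation therefore starts from compound 1 at 11000 nM, with no shift beyond the scatter in either direction in this assay. The expected step is a 1.1-fold higher number from compound 1 to compound 4 (0.04 log units; within the scatter), which stays within the scatter. The estimated value for compound 4 is 12000 nM, with an expected range of 4500 nM to 25000 nM.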

Compound 4, half-maximal inhibitory concentration: 2400 nM
Beside the measured number, compound 4's estimate is 5.0-fold (0.70 log units) above it; measured number below the stated range.
By their numbers in this assay, from the lowest: compound 4; then compounds 1 and 2 (each within the scatter of the next). At a limit, above all of these: compound 3.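

In this assay, for the compounds shown here, 2,3-dimethyl-2H-indazol-6-yl in place of 1H-benzimidazol-6-yl gives a 4.6-fold lower number from compound 1 to compound 4 (0.66 log units; beyond the scatter), the first step that can be read from a single exchange and one that lies beyond the scatter. Going by these compounds alone, the group carried on this nitrogen on an aromatic ring therefore changes the read-out with the rest of compound 1 held constant, which the earlier compounds could not show. The exchange alters the ring arrangement, the two methyl groups and the hydrogen-bond counts together, and nothing measured here bears on which of these accounts for the step.

Open, as far as these compounds go, is whether the step survives with an ethyl group in place of either methyl. Also open, from the compounds shown here alone, is whether an amine on the same ring system keeps it.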